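The compounds below may be only part of what the source reports. "The series", "measured", "known", "first", "only" and "open" are said of these compounds alone.

Values in an assay on isolated protein for inhibition of liver carboxylesterase 1 (Homo sapiens) (a higher number here means a weaker inhibitor, a lower number a stronger inhibitor), for the three measured compounds:

compound 1 `O=C(CCCCCCc1ccccc1)c1ncno1` gives 0.7 nM
compound 2 `O=C(CCCCCCc1ccccc1)c1ncon1` gives 10 nM
compound 3 `O=C(CCCCCCc1ccccc1)c1nncs1` gives 100 nM

Compound 3 carries the highest number of the three. Its nearest neighbour is compound 2, a step of a 10-fold higher number from compound 2 to compound 3 (1.00 log units; beyond the scatter); its furthest is compound 1, a step of a 140-fold higher number from compound 1 to compound 3 (2.15 log units; beyond the scatter). The remaining pair shows a 14-fold higher number from compound 1 to compound 2 (1.15 log units; beyond the scatter). Every measured step in the series is an exchange of the five-membered ring on the carbonyl carbon, and none of them stayed within the scatter.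

Compound 4 `O=C(CCCCCCc1ccccc1)c1nnn[nH]1` differs from compound 3 in one place: 1H-tetrazol-5-yl in place of 1,3,4-thiadiazol-2-yl on a carbonyl carbon. No measured pair contains the entering ring, so the direction of this step is not fixed by any step shown. What the three steps do show is that exchanging this ring moved the number beyond the scatter each time, so a step of comparable size is expected here rather than one within the scatter. Read against the pattern of compound 3 sitting at the weak end already, the expected step is a 3.0-fold higher number from compound 3 to compound 4 (0.48 log units; beyond the scatter), upward. Compound 4 is therefore estimated at 300 nM, within a range of 40 nM to 3000 nM.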

Compound 4, half-maximal inhibitory concentration: 80 nM
Compound 4: the middle estimate sits 3.8-fold (0.57 log units) above what was measured, and the stated range covers the measured number.
By their numbers in this assay, from the lowest: compound 1; then compound 2; then compounds 4 and 3 (each within the scatter of the next).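

Working notes: in this assay an exchange of the ring on the carbonyl carbon does not always move the number beyond the scatter (a 1.3-fold lower number from compound 3 to compound 4 (0.10 log units; within the scatter)), even though 1H-tetrazol-5-yl carries a hydrogen-bond donor and 1,3,4-thiadiazol-2-yl carries none. The other two steps (an 8.0-fold higher number from compound 2 to compound 4 (0.90 log units; beyond the scatter); a 110-fold higher number from compound 1 to compound 4 (2.06 log units; beyond the scatter)) place 1H-tetrazol-5-yl with 1,3,4-thiadiazol-2-yl, well away from 1,2,4-oxadiazol-5-yl, so a ring with four nitrogens and one with two nitrogens and a sulfur sit level here. Nothing shown explains this closeness.

Open: how a carboxylic acid or a 1,3-oxazol-2-yl ring on the carbonyl carbon would stand against these rings, and whether a methyl on the tetrazole nitrogen would move the number. Also open, as far as these compounds go, is whether the same ring order holds with a shorter chain.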